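Swapping the octyl chain for a bromobenzyl on the triazole

A few compounds are considered here, and "the series" means these few. Any claim that something is new, unique, unknown or untested is made for them only; others in the source may bear on it.

Measured compounds:
- compound 1 `CCCCCCCCn1cc(/C=C/C(=O)c2ccc(NC(=O)CN3CCN(c4ccccc4)CC3)cc2)nn1`: 31900 nM
- compound 2 `O=C(CN1CCC(Cc2ccccc2)CC1)Nc1ccc(C(=O)/C=C/c2cn(Cc3ccc(Br)cc3)nn2)cc1`: 54500 nM
- compound 3 `CCCCCCCCn1cc(/C=C/C(=O)c2ccc(N)cc2)nn1`: 31000 nM

All three compounds were tested in a functional assay on MCF7 cells (Homo sapiens) for inhibition, read by MTT assay; on this read-out lower numbers stand for stronger inhibition and higher numbers for weaker inhibition. Compound 1 gives 31900 nM and stands second highest of the three numbers; compound 3 with 31000 nM lies nearest, and compound 2 with 54500 nM lies furthest, yet both of these gaps fall within the scatter of repeated measurements, so the three compounds cannot be told apart by these numbers alone.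

Compound 4 `O=C(CN1CCN(c2ccccc2)CC1)Nc1ccc(C(=O)/C=C/c2cn(Cc3ccc(Br)cc3)nn2)cc1` has not yet been measured. It differs from compound 1 in one place: 4-bromophenyl in place of heptyl on a saturated chain carbon bound to an aromatic nitrogen. Going by the values given here, no measured pair shows this change on its own. Compound 2 carries the same 4-bromobenzyl group on the triazole together with a different amide-linked amine, and its value sits close to those of compound 1 and compound 3. Compound 4 is therefore expected to stay near compound 1, with a step of a 1.3-fold higher number from compound 1 to compound 4 (0.10 log units; within the scatter) that is expected to be none beyond the scatter. The estimate for compound 4 in this assay is 40000 nM, with a range from 15000 nM to 100000 nM.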

Compound 4, half-maximal inhibitory concentration: 49200 nM
The estimate for compound 4 lay 1.2-fold (0.09 log units) below the measured number; low and high end bracket the measured number.
By their numbers in this assay, from the lowest: compounds 3, 1, 4 and 2 (each within the scatter of the next).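

In this assay, the exchange of the octyl chain of compound 1 for the 4-bromobenzyl group of compound 4 gives a 1.5-fold higher number from compound 1 to compound 4 (0.19 log units; within the scatter). Going by these compounds alone, this is the first direct reading of this change on its own, as the earlier compounds differed in more than one place: on a saturated chain carbon bound to an aromatic nitrogen, a 4-bromophenyl in place of heptyl leaves a difference that cannot be told from the scatter. No measurement of any property bears on this result, so no explanation can be offered for it.

The compounds shown leave open whether an unsubstituted benzyl, a shorter chain such as butyl, or a chain ending in an amine or a carboxylic acid would read the same at this position. They also leave open whether the same exchange reads alike on other amide-linked amines.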